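The source may hold more compounds than are shown below. What is called first, only, known or untested is meant among the compounds shown, and "the series" means these compounds.

Measured compounds in a functional assay on HeLa cells (Homo sapiens) for antiproliferative activity, read by sulforhodamine B assay, with a stated time of 48 h; on this read-out lower numbers stand for stronger inhibition and higher numbers for weaker inhibition:

compound 1, `COc1ccc2nc(-c3ccc(N/C=C\C(=O)c4cc(OC)c(OC)c(OC)c4)cc3)sc2c1`, 14100 nM
compound 2, `COc1cc(C(=O)/C=C\Nc2ccc(-c3nc4cc(OC)c(OC)c(OC)c4s3)cc2C)c(Br)c(OC)c1OC`, 14300 nM
compound 3, `COc1ccc2nc(-c3ccc(N/C=C\C(=O)c4cc(OC)c(OC)c(OC)c4Br)cc3)sc2c1`, 8020 nM

Compound 3 and compound 1 differ in one place only:

hydrogen in place of bromo on an aromatic carbon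

On this change the read-out moved by a 1.8-fold higher number from compound 3 to compound 1 (0.25 log units; within the scatter), so the two values tell the same story. Compound 2 stands on a different core from compound 3; the difference between the two cores is not broken down here, and the values of compound 2 and compound 3 lie within the scatter of each other.

Compound 4, `COc1cc(C(=O)/C=C\Nc2ccc(-c3nc4cc(OC)c(OC)c(OC)c4s3)cc2C)cc(OC)c1OC`, has not yet been measured in this assay. It differs from compound 2 by the following change:

hydrogen in place of bromo on an aromatic carbon

The place of the change is described in the same words as for the step from compound 3 to compound 1, so it is the same change on the core of compound 2. On that single precedent, a step of a 1.4-fold higher number from compound 2 to compound 4 (0.15 log units; within the scatter) is expected from compound 2 to compound 4, because the earlier step was a 1.8-fold higher number from compound 3 to compound 1 (0.25 log units; within the scatter). The number for compound 4 is estimated at 20000 nM, with a range from 8000 nM to 50000 nM expected.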

Compound 4, half-maximal inhibitory concentration: 11100 nM
Beside the measured number, compound 4's estimate is 1.8-fold (0.26 log units) above it; low and high end bracket the measured number.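

In this assay, hydrogen in place of bromo on an aromatic carbon gives a 1.3-fold lower number from compound 2 to compound 4 (0.11 log units; within the scatter), a step too small to read as a real change. Set beside the same change on the other core, the two steps cannot be told apart, even though their printed directions are opposite: the same change on two cores in this assay, a 1.8-fold higher number (0.25 log units; within the scatter) from compound 3 to compound 1 and a 1.3-fold lower number (0.11 log units; within the scatter) from compound 2 to compound 4, 2.3-fold (0.36 log units) apart, within the scatter of two such steps. This shows that on these two cores the exchange leaves the number within the usual scatter, so the result carries over only as the absence of a readable effect; it does not show a direction for the change, and two pairs cannot show that the same would hold on any other core in the series.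

The compounds shown leave open whether a chloro group, a nitrile or an amine at this place would move the number beyond the scatter. They also leave open what the extra methoxy groups and the methyl group on the core of compound 2 each contribute, since these differ together between the two cores.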